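This account rests on a few compounds, and the source may have more. Where it says the series, first, only, none or still open, it means among the compounds named here.

The series shares one core, carried by compound 1 `CO[C@H]1C[C@H](Oc2cc(F)c(F)c(-c3ccc4c(c3)CC[C@H](CCC(=O)O)O4)c2)C1`, compound 2 `CO[C@H]1C[C@H](Oc2cc(F)c(F)c(-c3cc(F)c(OCCCC(=O)O)c(F)c3)c2)C1` and compound 3 `CO[C@H]1C[C@H](Oc2cc(F)c(F)c(-c3cc(C)c(OCCCC(=O)O)c(C)c3)c2)C1`, which differ in the arm that bears the acid. In a functional assay on CHO cells for agonist activity at Free fatty acid receptor 1 (Homo sapiens), read by calcium flux (a lower number here means that less compound is needed, a higher number that more compound is needed for the effect), compound 1 gives only a limit, > 100000 nM. Compound 2 likewise reaches only a limit of > 100000 nM in this assay. Compound 3 also sits at a limit, > 100000 nM. Among the measured compounds shown here, compound 2 thus stands together with the others at the limit of > 100000 nM in this assay, at which 3 of the 3 values shown sit, and no measured step exists in the set. Compound 4 `CO[C@H]1C[C@H](Oc2cc(F)c(F)c(-c3cc(F)c(OCCCCCCC(=O)O)c(F)c3)c2)C1` differs from compound 2 by 3-carboxypropyl in place of carboxy on a saturated chain carbon, three bonds along the chain from an oxygen on an aromatic ring. Nothing measured here speaks for a gain from the longer chain. Compound 4 is expected at 100000 nM, between 10000 nM and 1000000 nM. The expected step from compound 2 to compound 4 is a number no higher from compound 2 to compound 4 (the limit leaves the size open), none beyond the scatter.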

Compound 4, half-maximal effective concentration: 3500 nM
For compound 4 the middle estimate is 29-fold (1.46 log units) above the measured one, and the stated range ends above it.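

In this assay, among the compounds shown here, the longer chain on this saturated chain carbon, three bonds along the chain from an oxygen on an aromatic ring, gives an at least 28-fold lower number from compound 2 to compound 4 (1.45 log units; beyond the scatter), the first measured step in the set. On these data alone, compound 2 gives only a limit, so the full size of this step stays unknown. Compound 4 is the only compound shown that gives a number rather than a limit: the limit of > 100000 nM in this assay, at which 3 of the 4 values shown sit.

As far as these compounds go, whether 4-carboxybutyl or 5-carboxypentyl would already clear that limit remains open. So does whether a still longer chain would lower the number further.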